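The source may hold more compounds than are shown below. What is called first, only, known or untested is meant among the compounds shown, and "the series" means these compounds.

Working notes on the series. Of the compounds shown here, three with a shared core have been read in a functional assay on HepG2 cells (Homo sapiens) for antiproliferative activity, read by MTT assay, with a stated time of 24 h (a higher number here means a weaker inhibitor, a lower number a stronger inhibitor), so far. Compound 1 (`COc1cccc(/C=C/C(=O)c2ccc(OC)c3c2OC(C)(C)C=C3)c1`) gives > 10000 nM as a limit of the assay. Compound 2 (`COc1ccc(C(=O)/C=C/c2ccccc2Cl)c2c1C=CC(C)(C)O2`) gives > 10000 nM as a limit too. Compound 3 (`COc1ccccc1/C=C/C(=O)c1ccc(OC)c2c1OC(C)(C)C=C2`) gives > 10000 nM as a limit as well, so it stands without a number of its own.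

Compound 4 (`COc1ccc(C(=O)/C=C/c2cc(Cl)ccc2O)c2c1C=CC(C)(C)O2`) carries 5-chloro-2-hydroxyphenyl in place of 2-methoxyphenyl on a double-bonded chain carbon bound to a double-bonded chain carbon.

The measured steps that bear on this are a step that the two limits leave unreadable from compound 1 to compound 3 and a step that the two limits leave unreadable from compound 2 to compound 3 and a step that the two limits leave unreadable from compound 1 to compound 2 as well. None of them has a readable size. Compound 4 is expected to stay near the limit in this assay because the limit of > 10000 nM in this assay, at which 3 of the 3 values shown sit, is all the series offers so far. Any number that does appear is expected on the stronger side of that limit. The expected change is an at least 1.1-fold lower number from compound 3 to compound 4 (0.04 log units; that floor lies within the scatter) and it remains a rough estimate. The estimated value for compound 4 is 9000 nM with an expected range from 2500 nM to 20000 nM as a wide estimate.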

Compound 4, half-maximal inhibitory concentration: 6640 nM
Compound 4: middle estimate off by 1.4-fold (0.13 log units), on the high side; low and high end bracket the measured number.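

In this assay compound 4 is the first compound to give a number rather than a limit, so a change at this place on a double-bonded chain carbon bound to a double-bonded chain carbon can now be sized, if only from one side, against the rest of the series: the limit of > 10000 nM in this assay, at which 3 of the 4 values shown sit.

The 5-chloro-2-hydroxyphenyl group gives an at least 1.5-fold lower number from compound 3 to compound 4 (0.17 log units; that floor lies within the scatter), an at least 1.5-fold lower number from compound 2 to compound 4 (0.17 log units; that floor lies within the scatter) and an at least 1.5-fold lower number from compound 1 to compound 4 (0.17 log units; that floor lies within the scatter). These three steps are only floors, so they do not show a change beyond the scatter, and the steps among compounds 1, 2 and 3 cannot be read.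

The compounds shown leave open whether the hydroxy or the chloro of the entering group carries the step, as neither appears alone on this ring with a readable number. Going by these compounds, how an amine or a carboxylic acid would read at this place also remains open.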